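A few compounds are considered here, and "the series" means these few. Any claim that something is new, unique, unknown or untested is made for them only; others in the source may bear on it.

Compound 2 `COc1ccc(C(=O)c2ccc3c(ccn3S(=O)(=O)c3cccc(/C=C/C(=O)NO)c3)c2)cc1` holds the lower of the two values measured in an assay on isolated protein for inhibition of protein deacetylase HDAC6 (Homo sapiens) (on this read-out lower numbers stand for stronger inhibition and higher numbers for weaker inhibition), where compound 2 gives 751 nM. For the measured compounds named here, its only neighbour is compound 1 `Cc1ccc(C(=O)c2ccc3c(ccn3S(=O)(=O)c3cccc(/C=C/C(=O)NO)c3)c2)cc1`, which in this assay gives 2750 nM; the single recorded step between them is a 3.7-fold lower number from compound 1 to compound 2 (0.56 log units; beyond the scatter), a clear though modest gain. Compound 3 `COc1ccc(C(=O)c2ccc3c(ccn3S(=O)(=O)c3cccc(/C=C/C(=O)NO)c3)c2)cc1OC` is derived from compound 2 by one change: methoxy in place of hydrogen on an aromatic carbon, so that the (4-methoxyphenyl)carbonyl group becomes a (3,4-dimethoxyphenyl)carbonyl group, the new methoxy standing ortho to the methoxy already present. Going by the values given here, only one measured step exists for comparison, and it describes a swap of one group for another on the same ring rather than the addition of a second methoxy. It therefore offers no direct guide to the present change. Lacking a step of the same kind, the expectation for compound 3 in this assay is a shift no larger than the scatter, if anything toward a lower number, the estimated step being a 1.3-fold lower number from compound 2 to compound 3 (0.10 log units; within the scatter). The estimate for compound 3 in this assay is 600 nM, with a range from 200 nM to 1800 nM.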

Compound 3, half-maximal inhibitory concentration: 1180 nM
Compound 3: middle estimate off by 2.0-fold (0.29 log units), on the low side, within the range that was stated.
By their numbers in this assay, from the lowest: compounds 2 and 3 (each within the scatter of the next); then compound 1.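

In this assay, placing methoxy on this aromatic carbon, ortho to a methoxy group and meta to a large group, gives a 1.6-fold higher number from compound 2 to compound 3 (0.20 log units; within the scatter) and so leaves the 3,4-dimethoxyphenyl and 4-methoxyphenyl groups indistinguishable on this read-out. The earlier step showed only what a swap of methyl for methoxy did on the ring, whereas this one shows that the ring can carry a second methoxy at this place with no change beyond the scatter, and a 2.3-fold lower number from compound 1 to compound 3 (0.37 log units; beyond the scatter) shows that the 3,4-dimethoxyphenyl group still stands apart from the 4-methylphenyl group of compound 1, though only modestly. Nothing available here offers an explanation for this result.

The compounds shown leave open whether a different group on this same carbon, such as fluorine, an amine or a carboxylic acid, would move the number beyond the scatter. They also leave open whether a longer chain such as ethoxy would be taken up here in the same way, and how a methoxy at this place would read with the first methoxy gone.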